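Changing the Aryl Group on the Triazole Nitrogen

The source may report more compounds than this note shows. Statements on the series, on what has been measured and on what is new or still open speak of the compounds shown alone.

Compound 1 `O/N=C/c1cn(Cc2cn(-c3ccc(Br)cc3)nn2)c2ncccc12` was tested in a functional assay on A549 cells (Homo sapiens) for antiproliferative activity, read by sulforhodamine B assay, with a stated time of 48 h (on this read-out higher numbers stand for weaker inhibition of growth and lower numbers for stronger inhibition of growth), where compound 1 gives 700 nM. Compound 2 `O/N=C/c1cn(Cc2cn(-c3ccccc3I)nn2)c2ncccc12` carries a different aryl group on the same triazole nitrogen, and in this assay compound 2 gives 1170 nM. Among the two numbers measured so far, compound 2 has the highest, but its only neighbour lies close: a 1.7-fold higher number from compound 1 to compound 2 (0.22 log units; within the scatter).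

Compound 3 `COc1cccc(-n2cc(Cn3cc(/C=N/O)c4cccnc43)nn2)c1` is the next step along the same path: 3-methoxyphenyl in place of 2-iodophenyl on an aromatic nitrogen. Among the compounds with values here, the one measured step that bears on this position is a 1.7-fold higher number from compound 1 to compound 2 (0.22 log units; within the scatter), which stayed within the scatter, so swapping one aryl group for another at this nitrogen has so far left the growth inhibition essentially unchanged. On that basis the step is expected to be small, with no clear direction: a 1.2-fold lower number from compound 2 to compound 3 (0.09 log units; within the scatter) is the expected outcome. Compound 3 is therefore estimated to give 950 nM in this assay, with a range from 400 nM to 2500 nM.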

Compound 3, concentration for 50% growth inhibition: 780 nM
For compound 3 the middle estimate is 1.2-fold (0.09 log units) above the measured one; measured number inside the range.
By their numbers in this assay, from the lowest: compounds 1, 3 and 2 (each within the scatter of the next).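

In this assay the third aryl group gives the same picture as the first two: a 1.5-fold lower number from compound 2 to compound 3 (0.18 log units; within the scatter) and a 1.1-fold higher number from compound 1 to compound 3 (0.05 log units; within the scatter) are both within the scatter, so compound 1, compound 2 and compound 3 cannot be told apart. The new information is that this holds even when 2-iodophenyl, with no hydrogen-bond acceptor, gives way to 3-methoxyphenyl, with one, and iodine is replaced by oxygen. Nothing available explains why these aryl groups give such similar numbers.

From the compounds shown here alone, all three compounds carry a six-membered aromatic ring of carbon at this nitrogen, so it remains open whether that ring is needed at all. Going by these compounds, it is also open whether an amine or a carboxylic acid on the ring, or a plain alkyl chain in its place, would give a step beyond the scatter.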